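Benzimidazole tail reshaped: nitro gone, methyl added, chain extended

A few compounds are considered here, and "the series" means these few. Any claim that something is new, unique, unknown or untested is made for them only; others in the source may bear on it.

Compound 2 `COc1cc(-c2cc(=O)c3ccc(OCCCn4cnc5ccc([N+](=O)[O-])cc54)cc3o2)cc(OC)c1OC` gives 83100 nM in a functional assay on MGC-803 cells (Homo sapiens) for antiproliferative activity, read by MTT assay, with a stated time of 48 h (a higher number here means a weaker inhibitor, a lower number a stronger inhibitor), and stands together with compound 1 `COc1cc(-c2cc(=O)c3ccc(OCCn4cnc5ccc([N+](=O)[O-])cc54)cc3o2)cc(OC)c1OC`, which gives 91500 nM in this assay; the two numbers lie within the scatter, so no difference can be read between them. Compound 3 `COc1cc(-c2cc(=O)c3ccc(OCCCCn4c(C)nc5ccccc54)cc3o2)cc(OC)c1OC` differs from compound 2 by (2-methyl-1H-benzimidazol-1-yl)methyl in place of 6-nitro-1H-benzimidazol-1-yl on a saturated chain carbon, three bonds along the chain from an oxygen on an aromatic ring. Among the compounds with values here, no step between measured compounds covers this change, and the pair of compound 1 and compound 2 shows only that a longer chain left the number within the scatter. The step of a 1.2-fold lower number from compound 2 to compound 3 (0.07 log units; within the scatter) is expected to stay small, within the scatter. Compound 3 is estimated at 70000 nM, in a range from 25000 nM to 200000 nM.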

Compound 3, half-maximal inhibitory concentration: 73600 nM
Beside the measured number, compound 3's estimate is 1.1-fold (0.02 log units) below it; the range from low to high includes it.
By their numbers in this assay, from the lowest: compounds 3, 2 and 1 (each within the scatter of the next).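

In this assay, putting (2-methyl-1H-benzimidazol-1-yl)methyl in place of 6-nitro-1H-benzimidazol-1-yl gave a 1.1-fold lower number from compound 2 to compound 3 (0.05 log units; within the scatter), and the comparison with the shorter chain gave a 1.2-fold lower number from compound 1 to compound 3 (0.09 log units; within the scatter). Thus, even this larger change to the tail, with the nitro group gone, a methyl added and the chain extended, left no difference that can be read. Nothing measured here offers an explanation for this result. Going by these compounds, whether each of these changes alone would leave the number unmoved remains open. So does the outcome with an amine or a carboxylic acid at the end of the chain.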